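A few compounds are considered here, and "the series" means these few. Any claim that something is new, unique, unknown or untested is made for them only; others in the source may bear on it.

Measured compounds:
- compound 1, `Cc1n[nH]c2ccc(-c3nc4cnc(N5CCN(C)CC5)cn4c3Nc3ccc(Cl)cc3)cc12`, 83.7%
- compound 2, `Cc1n[nH]c2ccc(-c3nc4cnc(N5CCN(C)CC5)cn4c3Nc3ccccc3)cc12`, 0%
- compound 3, `Cc1ccc(C)c(Nc2c(-c3ccc4[nH]nc(C)c4c3)nc3cnc(N4CCN(C)CC4)cn23)c1`, 0%

In a functional assay on MV4-11 cells (Homo sapiens) for inhibition, with a stated time of 120 h, tested at 10 uM (a higher number here means more inhibition at the concentration tested (going by the name of the read-out), a lower number less inhibition), compound 3 stands level with compound 2, the two together at the bottom of the three numbers, and compound 1 is the only one clearly apart, the step of a number 83.7 percentage points lower from compound 1 to compound 3 (beyond the scatter) lying beyond the scatter. The step of no change at the digits printed from compound 2 to compound 3 (within the scatter) is within the scatter.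

Compound 4, `Cc1cc(Br)ccc1Nc1c(-c2ccc3[nH]nc(C)c3c2)nc2cnc(N3CCN(C)CC3)cn12`, is not yet measured. The change from compound 3 is 4-bromo-2-methylphenyl in place of 2,5-dimethylphenyl on a nitrogen on an aromatic ring.

Going by the values given here, the steps that bear on this are a number 83.7 percentage points lower from compound 1 to compound 2 (beyond the scatter) and a number 83.7 percentage points lower from compound 1 to compound 3 (beyond the scatter): both remove 4-chlorophenyl and both lose the whole signal. Compound 4 carries 4-bromo-2-methylphenyl, which shares a halogen on the phenyl with compound 1 while keeping one methyl as in compound 3. Among the compounds with values here, no measured step tests this combination, so the expectation is a rise from compound 3, a number 45 percentage points higher from compound 3 to compound 4 (beyond the scatter), but with wide uncertainty. Compound 4 is estimated at 45%, within 0% to 90%.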

Compound 4, a percentage reported as inhibition, at one concentration (the size of the read-out at that concentration, not a potency): 59.4%
Beside the measured number, compound 4's estimate is 14.4 percentage points below it; the range from low to high includes it.
By their numbers in this assay, from the lowest: compounds 2 and 3 (each within the scatter of the next); then compound 4; then compound 1.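

Activity at this position in this assay is not confined to the 4-chlorophenyl of compound 1: the 4-bromo-2-methylphenyl group restores much of the signal, with a number 59.4 percentage points higher from compound 3 to compound 4 (beyond the scatter) and a number 59.4 percentage points higher from compound 2 to compound 4 (beyond the scatter) as the two large steps. Against compound 1 the signal is only partly recovered, a number 24.3 percentage points lower from compound 1 to compound 4 (beyond the scatter) being a modest step, and because this step swaps the chloro for bromo and adds a methyl at once, it cannot assign the loss to either change. No measurement at hand accounts for these steps.

As far as these compounds go, whether 4-bromophenyl without the methyl or 4-chloro-2-methylphenyl would keep the signal remains open. So does whether the signal needs a halogen at all, which a 4-methoxyphenyl or 4-methylphenyl group on the same nitrogen would test.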